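This account rests on a few compounds, and the source may have more. Where it says the series, first, only, none or still open, it means among the compounds named here.

Measured compounds:
compound 1 `CC(C)(C)c1ccc(C(=O)NCc2ccc(NS(C)(=O)=O)cc2)cc1`, 44 nM
compound 2 `CC(C)(C)c1ccc(C(=O)NCc2ccc(N)cc2Cl)cc1`, 46 nM

In an assay on HeLa cells with Bile acid receptor (Homo sapiens) as the target, read by a luciferase reporter, with a stated time of 24 h (a lower number here means that less compound is needed, a higher number that more compound is needed for the effect), compound 1 gives 44 nM, and compound 2 gives 46 nM. The two numbers lie within the usual scatter of each other, so neither compound can be set apart from the other on this evidence. Compound 3 `CCOc1ccc(CNC(=O)c2ccc(C(C)(C)C)cc2)cc1` has not yet been measured. It differs from compound 1 in one place: ethoxy in place of methanesulfonamido on an aromatic carbon, on an aromatic carbon para to a large group. Among the measured compounds shown here, no measured pair in this set shows what such a change does, so the outlook rests on the two values alone. A modest rise in this assay is expected for the step of a 2.0-fold higher number from compound 1 to compound 3 (0.31 log units; beyond the scatter), though a result that stays within the scatter of compound 1 would not be surprising. Compound 3 is estimated at 90 nM, with a range from 30 nM to 300 nM.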

Compound 3, half-maximal effective concentration: 160 nM
Estimate against measurement, compound 3: 1.8-fold (0.25 log units) below; the measured number falls inside the stated range.
By their numbers in this assay, from the lowest: compounds 1 and 2 (each within the scatter of the next); then compound 3.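

In this assay, among the compounds shown here, the exchange of methanesulfonamido for ethoxy on an aromatic carbon para to a large group gives a 3.6-fold higher number from compound 1 to compound 3 (0.56 log units; beyond the scatter) and is the first change in this set with a size that can be read. It shows that this position is not indifferent to what it carries, and that ethoxy does not take the place of methanesulfonamido here without a loss. The change alters several things together, since methanesulfonamido has 5 heavy atoms and 1 hydrogen-bond donor while ethoxy has 3 heavy atoms and 0 hydrogen-bond donors, and nothing available explains the rise. The compounds shown leave open how a methoxy group, a hydroxyl group or an amine alone would fare on this aromatic carbon. They also leave open whether a longer chain than ethoxy would shift the number further.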